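From phenyl to 4-methylphenyl on compound 1

The source may report more compounds than this note shows. Statements on the series, on what has been measured and on what is new or still open speak of the compounds shown alone.

Compound 1 `CNC(=O)c1cc(Oc2ccc(NC(=O)c3nccc(-c4ccccc4)n3)cc2)ccn1`: 39100 nM
Compound 2 `CNC(=O)c1cc(Oc2ccc(NC(=O)c3cc(-c4ccc(F)cc4)ncn3)cc2F)ccn1`: > 100000 nM (a limit of the assay)

The two compounds were tested in a functional assay on MCF7 cells (Homo sapiens) for cytotoxicity, read by MTT assay, with a stated time of 72 h; on this read-out higher numbers stand for weaker inhibition and lower numbers for stronger inhibition. Among the compounds with values here, compound 1 gives 39100 nM, the only actual number available so far. Compound 2 is recorded only as a limit, > 100000 nM. Compound 1 therefore serves as the sole numerical reference point for what follows.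

The next compound is compound 3 `CNC(=O)c1cc(Oc2ccc(NC(=O)c3nccc(-c4ccc(C)cc4)n3)cc2)ccn1`, which differs from compound 1 in a single place: methyl in place of hydrogen on an aromatic carbon. This is methyl in place of hydrogen on an aromatic carbon, para to a large group, so that phenyl becomes 4-methylphenyl.

Within the data shown here, no measured pair of compounds differs in one place alone, so the data offer no direct guide to the size of such a step. With nothing to favour either direction, the change is expected to stay within the usual scatter, and a 1.2-fold higher number from compound 1 to compound 3 (0.06 log units; within the scatter) is the expected step. Starting from compound 1 at 39100 nM, compound 3 is therefore expected to remain weak in this assay. The estimate for compound 3 is an expected 45000 nM, with a range of 15000 nM to 100000 nM.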

Compound 3, half-maximal inhibitory concentration: 44300 nM
Estimate against measurement, compound 3: 1.0-fold (0.01 log units) above, and the stated range covers the measured number.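

In this assay, the change from phenyl to 4-methylphenyl gives the series its first readable step between compounds that differ in one place: a 1.1-fold higher number from compound 1 to compound 3 (0.05 log units; within the scatter). Methyl in place of hydrogen on an aromatic carbon, para to a large group, therefore leaves the read-out unchanged within the scatter, so this place on the ring accepts a single added carbon with no measurable effect on the number, and neither compound can be ranked above the other. Compound 2 differs from compound 1 in more than one place and remains only a limit of the assay, so it offers no comparison for this step: the limit of > 100000 nM in this assay, at which 1 of the 3 values shown sits.

One small group at one place cannot show how far the read-out responds to change here, and an amine, a carboxylic acid or a longer chain in place of the methyl might or might not move the number beyond the scatter. On these data alone, it also remains open whether any change at this place could bring stronger inhibition in this assay, or whether the weak values of compound 1 and compound 3 are set by the shared core.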